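Thiourea on the ring nitrogen of compound 1

This account rests on a few compounds, and the source may have more. Where it says the series, first, only, none or still open, it means among the compounds named here.

The shared core is seen in compound 1 `NC(=O)c1c(NC(=O)c2ccccc2Cl)sc2c1CCNC2`. Among the compounds with values here, in a functional assay on HL-60 cells (Homo sapiens) for antiproliferative activity, with a stated time of 24 h (a higher number here means a weaker inhibitor, a lower number a stronger inhibitor), compound 1 gives 18600 nM, the second highest of the three numbers so far; compound 3 `Cc1ccc(C(=O)Nc2sc3c(c2C(N)=O)CCN(Cc2ccc(Cl)cc2Cl)C3)cc1` gives 19900 nM and compound 2 `Cc1ccc(C(=O)Nc2sc3c(c2C(N)=O)CCN(Cc2c(Cl)cccc2Cl)C3)cc1` gives 10000 nM, and both lie within the scatter of compound 1, so no order among the three is claimed. Within the data shown here, the only step measured so far, a 2.0-fold higher number from compound 2 to compound 3 (0.30 log units; within the scatter), moves a substituent on a saturated chain carbon bound to the ring amine nitrogen and stays within the scatter. Compound 4 `NC(=O)c1c(NC(=O)c2ccccc2Cl)sc2c1CCN(C(=S)Nc1ccccc1Br)C2` arises from compound 1 by a group of 10 heavy atoms (7 carbon, 1 nitrogen, 1 sulfur, 1 bromine; one six-membered aromatic ring of carbon only) in place of a hydrogen atom, on an amine nitrogen in a ring. Among the measured compounds shown here, no measured step covers a hydrogen giving way to a group on that ring nitrogen: compounds 2 and 3 carry groups there but also differ from compound 1 in the amide aryl, so only their values speak. Given that the one known step, a 2.0-fold higher number from compound 2 to compound 3 (0.30 log units; within the scatter), is within scatter, compound 4 is expected to give about 13000 nM, between 4000 nM and 40000 nM, a step of a 1.4-fold lower number from compound 1 to compound 4 (0.16 log units; within the scatter) that is expected to stay within the scatter.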

Compound 4, half-maximal inhibitory concentration: 9090 nM
For compound 4 the middle estimate is 1.4-fold (0.16 log units) above the measured one; the measured number falls inside the stated range.
By their numbers in this assay, from the lowest: compounds 4, 2, 1 and 3 (each within the scatter of the next, the first and the last beyond it).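

In this assay, within the data shown here, replacing the hydrogen on the amine nitrogen in a ring gives a 2.0-fold lower number from compound 1 to compound 4 (0.31 log units; beyond the scatter), the first step at this position measured with the rest of the molecule unchanged. The step is modest, but it shows that this nitrogen need not keep its hydrogen for activity in these cells, and that a group of 10 heavy atoms with one six-membered aromatic ring can sit there without the number rising. Nothing available here explains the step.

The compounds shown leave open which part of the entering group matters, the thiourea or the bromine-bearing aromatic ring. A urea with oxygen in place of the sulfur, a thiourea with an unsubstituted phenyl ring, or a small methyl group on the ring nitrogen would each separate these parts.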